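The compounds below may be only part of what the source reports. "The series", "measured", "known", "first", "only" and "open" are said of these compounds alone.

Compound 1, `CC(C)c1cccc(C(C)C)c1OC(=O)NC(=O)OCc1ccccc1`, in an assay on microsomes from intestine for inhibition of acyl-CoA:cholesterol acyltransferase (Oryctolagus cuniculus) (on this read-out higher numbers stand for weaker inhibition and lower numbers for stronger inhibition), gives 77 nM. Compound 2, `CCCCCCCCOC(=O)NC(=O)Oc1c(C(C)C)cccc1C(C)C`, in this assay gives 250 nM, and compound 3, `CCCCCCCC(C)OC(=O)NC(=O)Oc1c(C(C)C)cccc1C(C)C`, gives 97 nM. Among the three numbers compound 3 stands second highest: its nearest neighbour is compound 1, with a step of a 1.3-fold higher number from compound 1 to compound 3 (0.10 log units; within the scatter), which is within the scatter, and its furthest is compound 2, with a step of a 2.6-fold lower number from compound 2 to compound 3 (0.41 log units; beyond the scatter), which lies beyond it.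

Compound 4, `CCCCCCCCC(C)OC(=O)NC(=O)Oc1c(C(C)C)cccc1C(C)C`, has not yet been measured in this assay. It differs from compound 3 by methyl in place of hydrogen on a saturated chain carbon, eight bonds along the chain from an oxygen next to a carbonyl group. Going by the values given here, two measured steps bear on this change. One is a 2.6-fold lower number from compound 2 to compound 3 (0.41 log units; beyond the scatter), a methyl added to the chain, though there on a saturated chain carbon bound to an oxygen next to a carbonyl group. The other is a 3.2-fold higher number from compound 1 to compound 2 (0.51 log units; beyond the scatter), where an open chain gave a higher number than the phenyl. Neither step matches the present change; one points to a lower number, the other to a higher one. One therefore expects a small step, a 1.0-fold higher number from compound 3 to compound 4 (0.01 log units; within the scatter), with no clear direction beyond the scatter. Compound 4 is expected to give 100 nM, with a range from 50 nM to 200 nM.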

Compound 4, half-maximal inhibitory concentration: 270 nM
For compound 4 the middle estimate is 2.7-fold (0.43 log units) below the measured one; the measured number lies above the stated range.
By their numbers in this assay, from the lowest: compounds 1 and 3 (each within the scatter of the next); then compounds 2 and 4 (each within the scatter of the next).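

In this assay, methyl in place of hydrogen on a saturated chain carbon, eight bonds along the chain from an oxygen next to a carbonyl group, is not a neutral change: it costs inhibition, with the step beyond the scatter (a 2.8-fold higher number from compound 3 to compound 4 (0.44 log units; beyond the scatter)). The same kind of change, methyl in place of hydrogen, went the other way on the saturated chain carbon bound to that oxygen (a 2.6-fold lower number from compound 2 to compound 3 (0.41 log units; beyond the scatter)), so across these two places the direction of the step depends on where along the chain the methyl enters, and a gain at one place says nothing about the other. No measurement shown here accounts for this difference between the two places.

From the compounds shown here alone, what remains open is whether a longer chain at this place would raise the number further, or whether the rise stops after this single added methyl. Going by these compounds, it is equally open how a hydroxyl group or a carboxylic acid at this place, or ethyl on the carbon bound to the oxygen, would read in this assay.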